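Swapping the Distal Aryl Ring on a Shared Sulfonamide Core

This account rests on a few compounds, and the source may have more. Where it says the series, first, only, none or still open, it means among the compounds named here.

Compound 1 `CN1CCc2ccc(NS(=O)(=O)c3ccc(-c4ccc(F)c(Cl)c4)cc3)cc2CC1`: 7.94 nM
Compound 2 `Cc1noc(C)c1-c1ccc(S(=O)(=O)Nc2ccc3c(c2)CCN(C)CC3)cc1`: 10 nM
Compound 3 `Cc1cc2c(cc1NS(=O)(=O)c1ccc(-c3ccc(Cl)cc3)cc1)CCN(C)CC2`: 15.9 nM

All three were tested in an assay on isolated protein for displacement of a labelled ligand from 5-hydroxytryptamine receptor 6 (Homo sapiens), read by radioligand binding; a lower number here means a stronger inhibitor, a higher number a weaker inhibitor. Among these numbers compound 2 stands second highest; compound 1 is nearest and compound 3 furthest, both within the scatter. Compound 4 `CN1CCc2ccc(NS(=O)(=O)c3ccc(-c4ccc(C#N)cc4)cc3)cc2CC1` differs from compound 2 by 4-cyanophenyl in place of 3,5-dimethyl-1,2-oxazol-4-yl on an aromatic carbon. For the measured compounds named here, the one comparable step, a 1.3-fold higher number from compound 1 to compound 2 (0.10 log units; within the scatter), also exchanged the outer ring and stayed within the scatter. The values of compound 2 and compound 3 differ by a similar small margin. For compound 4 the step of no change at the digits printed from compound 2 to compound 4 (within the scatter) is therefore expected to remain within the scatter. Compound 4 is estimated at 10 nM, with a range from 4 nM to 25 nM.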

Compound 4, inhibition constant: 25.1 nM
Compound 4: middle estimate off by 2.5-fold (0.40 log units), on the low side, outside the stated range (above it).
By their numbers in this assay, from the lowest: compounds 1, 2, 3 and 4 (each within the scatter of the next, the first and the last beyond it).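

In this assay, the outer ring at this position is not freely interchangeable: 4-cyanophenyl gives a 2.5-fold higher number from compound 2 to compound 4 (0.40 log units; beyond the scatter) and a 3.2-fold higher number from compound 1 to compound 4 (0.50 log units; beyond the scatter). For the compounds shown here, both steps are modest, but they are the first here to go beyond the scatter. The ring exchange between 3-chloro-4-fluorophenyl and 3,5-dimethyl-1,2-oxazol-4-yl did not.

From the compounds shown here alone, whether an unsubstituted phenyl or a piperidine ring would fall with compound 1 or with compound 4 stays open. Nothing shown explains why 4-cyanophenyl gives the higher number.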